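Chloro in place of hydrogen on the core of compound 3

A few compounds are considered here, and "the series" means these few. Any claim that something is new, unique, unknown or untested is made for them only; others in the source may bear on it.

Three alkynes each carry one measurement in a functional assay on LS174T cells (Homo sapiens) for inhibition, with a stated time of 4 days, tested at 1 uM; a higher number here means a stronger effect of the compound at the concentration tested, a lower number a weaker effect. Compound 1 `Fc1cccc(F)c1C#Cc1cccc2[nH]ncc12` gives 19.8% and compound 2 `Fc1cccc(F)c1C#Cc1ccc2cn[nH]c2c1` gives 81.5%. Compound 3 `Fc1cccc(F)c1C#Cc1cnc2ccccc2c1` gives 41.7%, the second highest of the three numbers: it stands beyond the scatter above compound 1 and beyond the scatter below compound 2. Compound 4 `Fc1cccc(F)c1C#Cc1cc2ccccc2nc1Cl` is not yet measured and differs from compound 3 in one place: chloro in place of hydrogen on an aromatic carbon. Among the measured compounds shown here, no measured pair shows this change, so its size is unknown here. The expected step of a number 3.3 percentage points higher from compound 3 to compound 4 (within the scatter) is small, within the scatter, with no firm direction. Compound 4 is therefore estimated at 45%, with a range from 20% to 72%.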

Compound 4, a percentage reported as inhibition, at one concentration (the size of the read-out at that concentration, not a potency): 28.4%
Estimate against measurement, compound 4: 16.6 percentage points above, and the stated range covers the measured number.
By their numbers in this assay, from the lowest: compounds 1 and 4 (each within the scatter of the next); then compound 3; then compound 2.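

In this assay, among the compounds shown here, chloro in place of hydrogen on an aromatic carbon next to the ring nitrogen gives a number 13.3 percentage points lower from compound 3 to compound 4 (beyond the scatter) and is the first single-place change with a measured size. This position therefore responds to substitution, and chloro here lowers the read-out rather than raising it. No available evidence accounts for this loss.

From the compounds shown here alone, whether the loss is specific to chloro or follows from any group on this carbon stays open. A methyl, methoxy or amine at the same place would separate the two cases.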